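Weak cytotoxic quinazoline: nitro group swapped for syringyl

The source may report more compounds than this note shows. Statements on the series, on what has been measured and on what is new or still open speak of the compounds shown alone.

Among the compounds with values here, compound 1 `O=C(/C=C/c1ccc([N+](=O)[O-])cc1)Nc1cc2c(Nc3ccc(F)c(Cl)c3)ncnc2cc1O[C@H]1CCOC1` is the only compound in this set with a numerical result. In a functional assay on PC-3 cells (Homo sapiens) for cytotoxicity, read by MTT assay, with a stated time of 72 h (a lower number here means a stronger inhibitor, a higher number a weaker inhibitor), compound 1 gives 22800 nM, which places it as a weak inhibitor. Compound 2 `COc1ccc(/C=C/C(=O)Nc2cc3c(Nc4ccc(F)c(Cl)c4)ncnc3cc2OC)cc1` is recorded in this assay as "not active" (no number reported). Compound 3 `COc1cc(/C=C/C(=O)Nc2cc3c(Nc4ccc(F)c(Cl)c4)ncnc3cc2OC)cc(OC)c1` is likewise recorded in this assay as "not active" (no number reported). Within the data shown here, no step between compounds 1, 2 and 3 is given, so only these outcomes can be read from them.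

Compound 4 `COc1cc(/C=C/C(=O)Nc2cc3c(Nc4ccc(F)c(Cl)c4)ncnc3cc2O[C@H]2CCOC2)cc(OC)c1O` is not yet measured. It differs from compound 1 in one place: 4-hydroxy-3,5-dimethoxyphenyl in place of 4-nitrophenyl on a double-bonded chain carbon bound to a double-bonded chain carbon. Among the measured compounds shown here, no step between two measured compounds is available to anchor the size of this change. Since compound 1 itself sits at a weak level of 22800 nM, and compounds 2 and 3 gave no number at all, compound 4 is expected to remain a weak inhibitor, with a step from compound 1 of a 1.3-fold higher number from compound 1 to compound 4 (0.12 log units; within the scatter) that is expected to be no larger than the usual scatter. The estimate for compound 4 in this assay is 30000 nM, expected to lie between 10000 nM and 100000 nM.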

Compound 4, half-maximal inhibitory concentration: 26500 nM
Compound 4: middle estimate off by 1.1-fold (0.05 log units), on the high side, within the range that was stated.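

In this assay, the exchange of 4-nitrophenyl for 4-hydroxy-3,5-dimethoxyphenyl on a double-bonded chain carbon bound to a double-bonded chain carbon gives a 1.2-fold higher number from compound 1 to compound 4 (0.07 log units; within the scatter). Compound 1 alone could not show whether its weak level depended on the 4-nitrophenyl group, and compound 4 shows that the same weak level is reached without that group. No measurement at hand explains why the two groups read alike.

The entries without a number for compounds 2 and 3 cannot be read as steps, since each differs from compound 1 and from compound 4 in more than one place. As far as these compounds go, it remains open whether any other group at this place, such as an amine, a carboxylic acid or a longer chain, would move the number beyond the scatter.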